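The source may report more compounds than this note shows. Statements on the series, on what has been measured and on what is new or still open speak of the compounds shown alone.

In a functional assay on the whole organism (strain Sprague-Dawley) for inhibition, with Rattus norvegicus as the target, with a stated time of 10 min (on this read-out higher numbers stand for an effect only at larger amounts of compound and lower numbers for an effect already at smaller amounts), three compounds have been measured:

Compound 1 `C=CCOc1ccccc1-c1ncc(C(=O)OCC)c(=O)[nH]1`: 0.5 mg/kg
Compound 2 `CCOC(=O)c1cnc(-c2ccccc2OCC2CC2)[nH]c1=O`: 0.3 mg/kg
Compound 3 `CCOC(=O)c1cnc(-c2ccccc2SC)[nH]c1=O`: > 25 mg/kg

Compound 3 gives > 25 mg/kg, which is a limit and not a number. That is the limit of > 25 mg/kg in this assay, at which 1 of the 3 values shown sits. Compound 4 `CCOC(=O)c1cnc(-c2ccccc2SCC)[nH]c1=O` differs from it by methyl in place of hydrogen on a saturated chain carbon bound to a sulfur.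

Among the measured compounds shown here, no measured step changes a sulfur-bound chain, so the evidence is indirect. The two large steps, an at least 50-fold higher number from compound 1 to compound 3 (1.69 log units; beyond the scatter) and an at least 83-fold higher number from compound 2 to compound 3 (1.92 log units; beyond the scatter), replace a longer oxygen-linked group with methylsulfanyl. They do not separate the effect of the sulfur from that of chain length. The step between the two oxygen-linked chains, a 1.7-fold lower number from compound 1 to compound 2 (0.22 log units; within the scatter), lies within the scatter.

A modest move to a lower number is therefore expected in this assay, and a reading at the limit remains quite possible. The expected change is an at least 1.6-fold lower number from compound 3 to compound 4 (0.22 log units; that floor lies within the scatter). Compound 4 is estimated at 15 mg/kg, with an expected range from 3 mg/kg to 50 mg/kg.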

Compound 4, dose for 50% inhibition: > 5 mg/kg
Compound 4: only a limit was reported; the forecaster's own chance of this, stated with the estimate: 50%; the middle value does not contradict the limit.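

Compound 3 and compound 4 both stand only as limits in this assay, and the step between them cannot be read. Even so, the longer ethylsulfanyl group stays well apart from the oxygen-linked groups, with an at least 16-fold higher number from compound 2 to compound 4 (1.22 log units; beyond the scatter) and an at least 10-fold higher number from compound 1 to compound 4 (1.00 log units; beyond the scatter). The added methyl on the saturated chain carbon bound to a sulfur therefore does not bring the sulfur-linked series to the numbers of compound 1 and compound 2, and the gap seen with methylsulfanyl is not closed by this one change.

On these data alone, whether allylsulfanyl or cyclopropylmethylsulfanyl, the direct sulfur counterparts of the groups in compound 1 and compound 2, would come closer stays open. As far as these compounds go, the actual numbers behind both limits also stay open, as does any effect of the added methyl itself.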